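A few compounds are considered here, and "the series" means these few. Any claim that something is new, unique, unknown or untested is made for them only; others in the source may bear on it.

Compound 1 `O=C(CCCCCCc1nc2ccccc2[nH]1)NO` in a functional assay on SK-OV-3 cells (Homo sapiens) for cytotoxicity (a lower number here means a stronger inhibitor, a higher number a weaker inhibitor), gives 2700 nM.
Compound 2 `COc1ccc(-c2ccc3nc(CCCCCCC(=O)NO)[nH]c3c2)cc1` in this assay gives 3100 nM.

Going by the values given here, compound 2 has the highest of the two numbers measured so far in this assay, but its nearest neighbour is compound 1, and the step of a 1.1-fold higher number from compound 1 to compound 2 (0.06 log units; within the scatter) is within the scatter, so the two are indistinguishable on these data.

Compound 3 `CN(C)c1ccc2nc(CCCCCCC(=O)NO)[nH]c2c1` has not yet been measured in this assay. It differs from compound 2 in one place: dimethylamino in place of 4-methoxyphenyl on an aromatic carbon.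

Among the compounds with values here, only one measured step bears on this change, namely a 1.1-fold higher number from compound 1 to compound 2 (0.06 log units; within the scatter), in which the 4-methoxyphenyl group entered at the same aromatic carbon without moving the number beyond the scatter. The group now entering, dimethylamino, sits at that same position, and nothing in the measured pairs speaks to it directly. The expectation is therefore that the step of a 1.0-fold lower number from compound 2 to compound 3 (0.01 log units; within the scatter) stays within the scatter, in no particular direction. Compound 3 is estimated at 3000 nM in this assay, with a range from 1200 nM to 7500 nM.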

Compound 3, half-maximal inhibitory concentration: 1200 nM
Compound 3: the middle estimate sits 2.5-fold (0.40 log units) above what was measured; the measured number falls inside the stated range.
By their numbers in this assay, from the lowest: compound 3; then compounds 1 and 2 (each within the scatter of the next).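

In this assay, going by these compounds alone, the only earlier change at this aromatic carbon, a 1.1-fold higher number from compound 1 to compound 2 (0.06 log units; within the scatter), left open the possibility that the number does not respond to what stands there, but dimethylamino shows that it can: set against hydrogen it gives a 2.3-fold lower number from compound 1 to compound 3 (0.35 log units; beyond the scatter), and set against 4-methoxyphenyl it gives a 2.6-fold lower number from compound 2 to compound 3 (0.41 log units; beyond the scatter), which makes compound 3 the strongest inhibitor of the three, though by modest steps. The two groups differ in heavy atoms and in that 4-methoxyphenyl carries a six-membered aromatic ring and dimethylamino has no ring, while their hydrogen-bond donor and acceptor counts are the same, so those counts do not separate them. No supporting information accounts for the difference between these groups.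

With one group at this carbon giving a lower number, the compounds shown do not tell whether the nitrogen or the absence of a ring goes with that change, which a methoxy group, a methylamino group or a ring amine such as morpholine at the same carbon would help to separate. They also leave open whether the step would hold with a longer chain on the shared core.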